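Piperidine nitrogen: benzyl to benzoyl in the CCR8 series

The source may hold more compounds than are shown below. What is called first, only, known or untested is meant among the compounds shown, and "the series" means these compounds.

Two compounds of the shared core have numbers in an in vitro functional assay on RBL cells for antagonist activity at C-C chemokine receptor type 8 (Homo sapiens), read by FLIPR and calcium flux; on this read-out higher numbers stand for weaker inhibition and lower numbers for stronger inhibition. Compound 1 `COc1ccc2nccc(C3CN(C4CCN(Cc5cc6ccccc6s5)CC4)C(=O)O3)c2c1` gives 794 nM, and compound 2 `COc1ccc2nccc(C3CN(C4CCN(Cc5ccc(Cl)c(Cl)c5)CC4)C(=O)O3)c2c1` gives 126 nM. Going by the values given here, the single measured step, a 6.3-fold lower number from compound 1 to compound 2 (0.80 log units; beyond the scatter), exchanges the aryl group on the saturated chain carbon bound to the ring amine nitrogen. Among the compounds with values here, on these two numbers compound 2 stands lowest, with compound 1 the only neighbour and that one well beyond the scatter.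

Compound 3 `COc1ccc2nccc(C3CN(C4CCN(C(=O)c5ccc(Cl)c(Cl)c5)CC4)C(=O)O3)c2c1` is not yet measured. It differs from compound 2 in one place: (3,4-dichlorophenyl)carbonyl in place of 3,4-dichlorobenzyl on an amine nitrogen in a ring. The 3,4-dichlorophenyl ring itself is kept, so the step from compound 1 to compound 2 does not speak to this change; it only shows that this aryl group, joined through a saturated chain carbon, gives the lowest number seen so far. Within the data shown here, no measured step alters the atom joining the aryl group to the ring nitrogen, so the expectation rests on the change alone and is uncertain. For compound 3 an expected step of a 24-fold higher number from compound 2 to compound 3 (1.38 log units; beyond the scatter) toward a higher number in this assay is taken, with a wide range. The estimate for compound 3 in this assay is 3000 nM, between 300 nM and 30000 nM.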

Compound 3, half-maximal inhibitory concentration: 6310 nM
For compound 3 the middle estimate is 2.1-fold (0.32 log units) below the measured one; the range from low to high includes it.
By their numbers in this assay, from the lowest: compound 2; then compound 1; then compound 3.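

The atom joining the aryl group to the amine nitrogen in a ring now proves to be a strong determinant of the number in this assay: exchanging 3,4-dichlorobenzyl for (3,4-dichlorophenyl)carbonyl gives a 50-fold higher number from compound 2 to compound 3 (1.70 log units; beyond the scatter) and is a larger step than the aryl exchange, which gave a 6.3-fold lower number from compound 1 to compound 2 (0.80 log units; beyond the scatter) in the earlier pair. The 3,4-dichlorophenyl ring does not keep the number low by itself: joined through the carbonyl, it ends above the (1-benzothiophen-2-yl)methyl group, with a 7.9-fold higher number from compound 1 to compound 3 (0.90 log units; beyond the scatter) as the result, so the order of these two aryl-bearing groups depends on the joining atom as well as on the ring. Nothing available gives a measured reason for the size of this step.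

Going by these compounds, the carbonyl step rests on a single aryl group, so it remains open whether the same exchange would cost as much with the 1-benzothiophen-2-yl ring. Also open, on these data alone, is how a sulfonyl link or a longer chain, such as a two-carbon chain to the 3,4-dichlorophenyl ring, would stand on the same amine nitrogen.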